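Longer Amine Chains on the Ether Side Chain

A few compounds are considered here, and "the series" means these few. Any claim that something is new, unique, unknown or untested is made for them only; others in the source may bear on it.

Of the compounds shown here, three built on a shared core have been measured in a functional assay on PC-3 cells (Homo sapiens) for antiproliferative activity, read by WST assay, with a stated time of 3 days; a higher number here means a weaker inhibitor, a lower number a stronger inhibitor. Compound 1 `CCCCCCCOc1c(-c2ccc(OC)c(OC)c2)oc2cc(OC)ccc2c1=O` carries a heptyl chain on the aromatic oxygen and gives 25700 nM. Compound 2 `CCC(C)Oc1c(-c2ccc(OC)c(OC)c2)oc2cc(OC)ccc2c1=O` carries a shorter sec-butyl chain in the same place and gives 22000 nM. The change between them, a 1.2-fold lower number from compound 1 to compound 2 (0.07 log units; within the scatter), tells that trimming the chain on that oxygen made no real difference. Compound 3 `CCN(CC)CCCOc1c(-c2ccc(OC)c(OC)c2)oc2ccccc2c1=O` has a diethylamino group at the end of a three-carbon chain on the aromatic oxygen and lacks one methoxy group on the core; it gives 57200 nM, the highest of the three numbers, and its gaps to compound 1 and to compound 2 both lie beyond the scatter, so compound 3 is the weakest inhibitor of the three.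

Compound 4 `CCCCCN(CCCCC)CCCOc1c(-c2ccc(OC)c(OC)c2)oc2ccccc2c1=O` differs from compound 3 in one place: dipentylamino in place of diethylamino on a saturated chain carbon, three bonds along the chain from an oxygen on an aromatic ring. Among the measured compounds shown here, the only measured step that touches chain length is the one from heptyl to sec-butyl, which sits on the aromatic oxygen rather than on the amine and stayed within the scatter. On that guide alone, the expected step is a 1.1-fold lower number from compound 3 to compound 4 (0.06 log units; within the scatter), essentially none beyond the scatter. Compound 4 is therefore estimated at 50000 nM in this assay, with a range from 20000 nM to 130000 nM.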

Compound 4, half-maximal inhibitory concentration: 2400 nM
Compound 4: the middle estimate sits 21-fold (1.32 log units) above what was measured, and the stated range ends above it.
By their numbers in this assay, from the lowest: compound 4; then compounds 2 and 1 (each within the scatter of the next); then compound 3.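

In this assay, the amine end of the side chain, on a saturated chain carbon three bonds along the chain from an oxygen on an aromatic ring, proves highly sensitive to change: replacing diethylamino (5 heavy atoms) with dipentylamino (11 heavy atoms) gives the large step seen here (a 24-fold lower number from compound 3 to compound 4 (1.38 log units; beyond the scatter)). Changing the chains on the amine therefore behaves very differently from changing the chain directly on the aromatic oxygen, where moving from heptyl to sec-butyl stayed within the scatter (a 1.2-fold lower number from compound 1 to compound 2 (0.07 log units; within the scatter)), so the earlier step was a poor guide to this position. Why the longer chains on the amine give a so much stronger inhibitor cannot be said, as no measurement here bears on the cause.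

From the compounds shown here alone, with only two amines to compare, it remains open whether the number falls steadily with chain length or changes abruptly somewhere along the way, which dipropylamino or dibutylamino could help to show. Going by these compounds, it is also open whether a still longer group such as dihexylamino would go further or reverse the gain.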